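Phenyl to 4-chlorophenyl on compound 1

The compounds below may be only part of what the source reports. "The series", "measured", "known", "first", "only" and "open" are said of these compounds alone.

In a functional assay on MCF7 cells (Homo sapiens) for cytotoxicity, read by MTT assay, with a stated time of 48 h (on this read-out lower numbers stand for stronger inhibition and higher numbers for weaker inhibition), compound 1 `CCN(CC)C(=S)SC(CC(=O)c1ccc(OC)cc1)c1ccccc1` gives 4500 nM, and compound 2 `CCN(CC)C(=S)SC(CC(=O)c1ccc(Cl)c(Cl)c1)c1ccccc1` gives 4500 nM, so the two stand level at the digits given. Compound 3 `CCN(CC)C(=S)SC(CC(=O)c1ccc(OC)cc1)c1ccc(Cl)cc1` keeps the 4-methoxyphenyl on the carbonyl carbon of compound 1 and changes phenyl to 4-chlorophenyl: chloro in place of hydrogen on an aromatic carbon. Among the measured compounds shown here, only one measured step offers any guidance, no change at the digits printed from compound 1 to compound 2 (within the scatter), with 3,4-dichlorophenyl in place of 4-methoxyphenyl on a carbonyl carbon. For the measured compounds named here, that step lies within the scatter, but it concerns a different place, and no measured pair tests chloro in place of hydrogen on this phenyl. No step beyond the scatter is therefore expected in this assay. The expected step is a 1.3-fold lower number from compound 1 to compound 3 (0.11 log units; within the scatter). For compound 3 the estimated value is 3500 nM, with an expected range of 1500 nM to 8000 nM.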

Compound 3, half-maximal inhibitory concentration: 16000 nM
The estimate for compound 3 lay 4.6-fold (0.66 log units) below the measured number; measured number outside the range, above it.
By their numbers in this assay, from the lowest: compounds 1 and 2 (each within the scatter of the next); then compound 3.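

Chloro in place of hydrogen on the phenyl gives a 3.6-fold higher number from compound 1 to compound 3 (0.55 log units; beyond the scatter) in this assay, which means weaker inhibition on this read-out. This phenyl is therefore sensitive to a single added chlorine, while the exchange on the carbonyl carbon, no change at the digits printed from compound 1 to compound 2 (within the scatter), shows no such sensitivity at that other place. Nothing available accounts for the loss.

One change at one place cannot separate an effect of chloro in particular from an effect of any group on an aromatic carbon para to a large group; a fluoro, a methyl, a methoxy or an amine there would test that. As far as these compounds go, it also remains open whether the step from adding chloro carries over when 3,4-dichlorophenyl stands on the carbonyl carbon, as in compound 2.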